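Pyridone series: microsomal clearance, methyl to isopropyl step

The compounds below may be only part of what the source reports. "The series", "measured", "known", "first", "only" and "open" are said of these compounds alone.

Measured compounds in an ADME assay on microsomes from liver (Homo sapiens) for metabolic stability; a higher number here means faster removal of the compound, a lower number slower removal:
compound 1 `CN(C)C(=O)CN1CCC(c2cc3c(-c4ccc(=O)n(C)c4)ccnc3[nH]2)CC1`, < 3 uL/min;
compound 2 `CC(C)n1cc(-c2ccnc3[nH]c(C4CCNCC4)cc23)ccc1=O`, < 3 uL/min;
compound 3 `CC(C)n1cc(-c2ccnc3[nH]c(C4CCN(CC(=O)N5CCCCC5)CC4)cc23)ccc1=O`, > 300 uL/min.

For compound 1 the figure is a limit of this assay, not a number, and it sits at the limit of < 3 uL/min in this assay, at which 2 of the 3 values shown sit. Compound 2 sits at the same limit. For compound 3 the figure is also a limit, (the limit of > 300 uL/min in this assay, at which 1 of the 3 values shown sits).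

Among the measured compounds shown here, the one measured step, an at least 100-fold higher number from compound 2 to compound 3 (2.00 log units; beyond the scatter), concerns a different change from the one to compound 4 `CC(C)n1cc(-c2ccnc3[nH]c(C4CCN(CC(=O)N(C)C)CC4)cc23)ccc1=O`, which is isopropyl in place of methyl on an aromatic nitrogen. For the measured compounds named here, no measured step covers this change, so its direction is uncertain; compound 3, which carries the isopropyl group, reaches the upper limit. Compound 4 is therefore expected at 40 uL/min (range 6 uL/min to 300 uL/min), the step of an at least 13-fold higher number from compound 1 to compound 4 (1.12 log units; beyond the scatter) being an estimate only.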

Compound 4, intrinsic clearance in a liver preparation (reported as CLH), per the amount of preparation that the assay uses: < 3 uL/min
Compound 4: a limit, no number (the forecaster's own chance of this, stated with the estimate: 35%); at least 13-fold (1.12 log units) between middle value and limit.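

In this assay compound 4 gives < 3 uL/min, a limit of the assay and not a number. With isopropyl kept on the aromatic nitrogen, dimethylamino in place of piperidin-1-yl on the carbonyl carbon gives an at least 100-fold lower number from compound 3 to compound 4 (2.00 log units; beyond the scatter), so isopropyl there does not by itself bring the upper limit. The steps to compound 4 from compound 1 and from compound 2 cannot be read, because their values share one limit: the limit of < 3 uL/min in this assay, at which 3 of the 4 values shown sit.

Any effect of isopropyl in place of methyl therefore stays hidden under that limit. Also open, from the compounds shown here alone, is where on the carbonyl carbon a pyrrolidin-1-yl or morpholin-4-yl group would fall in this assay.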